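Aryl substituent swaps within one cytotoxicity series

The source may report more compounds than this note shows. Statements on the series, on what has been measured and on what is new or still open speak of the compounds shown alone.

In a functional assay on SGC-7901 cells (Homo sapiens) for cytotoxicity, read by MTT assay, with a stated time of 48 h (a lower number here means a stronger inhibitor, a higher number a weaker inhibitor), compound 2 `Cc1ccccc1-c1nnc(SCCn2c([N+](=O)[O-])cnc2C)o1` gives 32300 nM, the highest number of the three, although all three sit within the scatter of one another: compound 1 `Cc1ncc([N+](=O)[O-])n1CCSc1nnc(-c2ccccc2)o1` gives 30100 nM and compound 3 `Cc1ncc([N+](=O)[O-])n1CCSc1nnc(-c2ccc(Cl)cc2)o1` gives 31900 nM. The measured steps of a 1.1-fold higher number from compound 1 to compound 2 (0.03 log units; within the scatter), a 1.1-fold higher number from compound 1 to compound 3 (0.03 log units; within the scatter) and a 1.0-fold lower number from compound 2 to compound 3 (0.01 log units; within the scatter) all stay within the scatter. Compound 4 `Cc1ncc([N+](=O)[O-])n1CCSc1nnc(-c2ccccc2O)o1` differs from compound 2 by hydroxy in place of methyl on an aromatic carbon. Going by the values given here, no measured step brings in a hydroxy group; the nearest precedents are the substituent swaps on the same six-membered ring, none of which shifted the number beyond the scatter. The step of a 1.0-fold lower number from compound 2 to compound 4 (0.00 log units; within the scatter) is therefore expected to remain within the scatter. For compound 4 the estimate is 32000 nM, with a range from 14000 nM to 70000 nM.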

Compound 4, half-maximal inhibitory concentration: 30500 nM
Estimate against measurement, compound 4: 1.0-fold (0.02 log units) above, and the stated range covers the measured number.
By their numbers in this assay, from the lowest: compounds 1, 4, 3 and 2 (each within the scatter of the next).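

Hydroxy, the one group here with a hydrogen-bond donor, sits on the aromatic carbon ortho to a large group, and in this assay the number stays within the scatter against methyl (a 1.1-fold lower number from compound 2 to compound 4 (0.02 log units; within the scatter)) and against hydrogen (a 1.0-fold higher number from compound 1 to compound 4 (0.01 log units; within the scatter)). Taken with the 4-chlorophenyl analogue (a 1.0-fold lower number from compound 3 to compound 4 (0.02 log units; within the scatter)), hydrogen, methyl, chloro and hydroxy on this ring all give numbers within the scatter of one another. No measurement available bears on what lies behind this flat result.

From the compounds shown here alone, whether an amine, a carboxylic acid or a longer chain at this position would move the number beyond the scatter remains open.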